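Cyclobutyl for cyclopropyl on an amide nitrogen

A few compounds are considered here, and "the series" means these few. Any claim that something is new, unique, unknown or untested is made for them only; others in the source may bear on it.

Three compounds share one core and differ only in the group on an amide-type nitrogen. Compound 1 `C=CCN(Cc1ccccc1C(F)(F)F)C(=O)C1CCN(S(=O)(=O)c2ccc3[nH]ncc3c2)CC1` carries an allyl group there, and in a functional assay on CHO cells for positive allosteric modulation of muscarinic acetylcholine receptor M5 (Homo sapiens), read by calcium flux (a lower number here means a smaller maximal response, a higher number a larger maximal response), compound 1 gives 79%. Compound 2 `O=C(C1CCN(S(=O)(=O)c2ccc3[nH]ncc3c2)CC1)N(Cc1ccccc1C(F)(F)F)C1CC1` carries a cyclopropyl group, but in this assay compound 2 gives "not determined" (no result reported), so there is no number to place it against compound 1. Compound 3 `O=C(C1CCN(S(=O)(=O)c2ccc3[nH]ncc3c2)CC1)N(Cc1ccccc1C(F)(F)F)C1CCC1` has not been measured. The change from compound 2 to compound 3 is cyclobutyl in place of cyclopropyl on an amide-type nitrogen, a small enlargement of a saturated carbon ring. Among the measured compounds shown here, since compound 2 offers no starting value, the step cannot be judged against the scatter; the only anchor is compound 1, and a change of this size on the same nitrogen is expected to move the maximal response little, if at all, beyond the scatter in this assay. Compound 3 is therefore expected to give roughly 75%, estimated to fall between 50% and 100%.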

Compound 3, largest response reached (reported as percent of maximum), in percent of the reference or control that the assay uses: 84%
For compound 3 the middle estimate is 9 percentage points below the measured one; the range from low to high includes it.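

Going from allyl to cyclobutyl on the amide-type nitrogen, this assay shows a number 5 percentage points higher from compound 1 to compound 3 (within the scatter), so this read-out does not separate the open allyl chain from the four-membered carbon ring at this position. As far as these compounds go, the step from compound 2 to compound 3 cannot be read: compound 2 has no reported result, so the effect of enlarging the ring from cyclopropyl to cyclobutyl remains unknown. Nothing available here offers an explanation for how closely compound 1 and compound 3 agree.

From the compounds shown here alone, it remains open whether a larger carbon ring such as cyclopentyl, a ring containing oxygen such as oxetanyl, or a longer chain such as n-butyl would give a similar maximal response on this nitrogen. These two results also say nothing about how much of each compound is needed to reach that response.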